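The source may report more compounds than this note shows. Statements on the series, on what has been measured and on what is new or still open speak of the compounds shown alone.

Compound 1 `N#CC1=C(N)Oc2c(N)cc3nc4ccccc4nc3c2C12C(=O)N(Cc1cnnn1-c1cccc(Br)c1)c1ccccc12`: 18900 nM
Compound 2 `Cc1ccc(-n2nncc2CN2C(=O)C3(C(C#N)=C(N)Oc4c(N)cc5nc6ccccc6nc5c43)c3ccccc32)cc1C`: > 50000 nM

In a functional assay on A549 cells (Homo sapiens) for antiproliferative activity, read by MTT assay, with a stated time of 48 h (on this read-out lower numbers stand for stronger inhibition and higher numbers for weaker inhibition), compound 1 gives 18900 nM. For compound 2 only a limit is reported in this assay, namely > 50000 nM. Compound 2 thus stands at the limit of > 50000 nM in this assay, at which 1 of the 2 values shown sits, and no number is known for it. Compound 3 `N#CC1=C(N)Oc2c(N)cc3nc4ccccc4nc3c2C12C(=O)N(Cc1cnnn1-c1cc(Cl)ccc1Cl)c1ccccc12` carries 2,5-dichlorophenyl in place of 3,4-dimethylphenyl on an aromatic nitrogen. For the measured compounds named here, only one measured step bears on this change: the number rose from a brominated phenyl to a dimethylphenyl, an at least 2.6-fold higher number from compound 1 to compound 2 (0.42 log units; beyond the scatter). Because an at least 2.6-fold higher number from compound 1 to compound 2 (0.42 log units; beyond the scatter) went up when the halogen left, moving back to a halogenated phenyl is expected to lower the number, an at least 2.0-fold lower number from compound 2 to compound 3 (0.30 log units; that floor lies within the scatter). Compound 3 is therefore estimated at 25000 nM, within 8000 nM to 60000 nM.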

Compound 3, half-maximal inhibitory concentration: 10900 nM
Beside the measured number, compound 3's estimate is 2.3-fold (0.36 log units) above it; the range from low to high includes it.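

With 2,5-dichlorophenyl on the aromatic nitrogen, this assay shows an at least 4.5-fold lower number from compound 2 to compound 3 (0.66 log units; beyond the scatter), so a second halogenated phenyl, carrying two chlorines rather than one bromine, also stands apart from the 3,4-dimethylphenyl. Between the two halogenated phenyls the step is a 1.7-fold lower number from compound 1 to compound 3 (0.24 log units; within the scatter), so the two are not told apart here. For compound 2 the value is a limit and not a number: the limit of > 50000 nM in this assay, at which 1 of the 3 values shown sits.

The compounds shown leave open whether the halogens themselves matter or any replacement of the two methyl groups would do. From the compounds shown here alone, how a phenyl bearing an amine or a carboxylic acid would read also remains open.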